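Amine cap variation at the shared core

This account rests on a few compounds, and the source may have more. Where it says the series, first, only, none or still open, it means among the compounds named here.

Measured so far:
- Compound 1 `CC(C)OC(=O)N1CCC(COc2ccc(N3CCN(C(=O)N(C)C)CC3)nc2)CC1`: > 10000 nM in a functional assay on CHO-K1 cells for agonist activity at Glucose-dependent insulinotropic receptor (Homo sapiens), read by a luciferase reporter, with a stated time of 5 h; on this read-out lower numbers stand for an effect already at smaller amounts and higher numbers for an effect only at larger amounts of compound
- Compound 2 `CC(C)OC(=O)N1CCC(COc2ccc(N3CCN(C(=O)c4ccco4)CC3)nc2)CC1`: 1900 nM in this assay

Compound 1 gives only a limit, (the limit of > 10000 nM in this assay, at which 1 of the 2 values shown sits). Within the data shown here, compound 2 gives the sole number in the set. Among the measured compounds shown here, the one measured step, an at least 5.2-fold lower number from compound 1 to compound 2 (0.72 log units; beyond the scatter), shows the cap on the ring amine changes the read-out. Compound 3 `CC(C)OC(=O)N1CCC(COc2ccc(N3CCN(S(=O)(=O)C(C)C)CC3)nc2)CC1` carries isopropylsulfonyl in place of (furan-2-yl)carbonyl on an amine nitrogen in a ring. That measured step does not involve a sulfonyl cap, so it bears only loosely; it shows that losing the aromatic cap can push the number up, toward the limit. A moderate rise is therefore expected, a 2.4-fold higher number from compound 2 to compound 3 (0.37 log units; beyond the scatter), with compound 3 estimated at 4500 nM, between 1500 nM and 12000 nM.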

Compound 3, half-maximal effective concentration: 300 nM
Beside the measured number, compound 3's estimate is 15-fold (1.18 log units) above it; measured number outside the range, below it.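

With a 6.3-fold lower number from compound 2 to compound 3 (0.80 log units; beyond the scatter) for isopropylsulfonyl in place of (furan-2-yl)carbonyl, the cap on this ring nitrogen need not be aromatic for the number to fall, and compound 3 holds the lowest number of the three. Isopropylsulfonyl in place of dimethylcarbamoyl gives an at least 33-fold lower number from compound 1 to compound 3 (1.52 log units; beyond the scatter) as the widest step here, and this step rests on a limit, not a number: the limit of > 10000 nM in this assay, at which 1 of the 3 values shown sits.

Still open, from the compounds shown here alone, is whether methylsulfonyl or phenylsulfonyl on this nitrogen would follow isopropylsulfonyl, and how a plain alkyl group there would read.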